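A Methyl Added to a Compound Without Measured Activity

A few compounds are considered here, and "the series" means these few. Any claim that something is new, unique, unknown or untested is made for them only; others in the source may bear on it.

Compound 1, `Cc1ccc(S(=O)(=O)Nc2ccc(C(=O)/C=C/c3ccccc3)cc2)cc1`: "not active" (no number reported)
Compound 2, `Cc1ccc(S(=O)(=O)Nc2ccc(-c3cc(-c4ccc([N+](=O)[O-])cc4)[nH]c(=O)n3)cc2)cc1`: 46300 nM

In a functional assay on HepG2 cells (Homo sapiens) for cytotoxicity, read by sulforhodamine B assay, with a stated time of 48 h (a lower number here means a stronger inhibitor, a higher number a weaker inhibitor), compound 1 gives "not active" (no number reported), so no single number marks where it stands. Compound 2 gives 46300 nM in this assay. Compound 3, `Cc1ccc(/C=C/C(=O)c2ccc(NS(=O)(=O)c3ccc(C)cc3)cc2)cc1`, differs from compound 1 by methyl in place of hydrogen on an aromatic carbon, phenyl becoming 4-methylphenyl. Among the measured compounds shown here, no step between measured compounds is known, and nothing recorded suggests this change would move the result in this assay beyond the usual scatter. Compound 3 is therefore expected to show 80000 nM, within a range from 30000 nM to 300000 nM, with a fair chance that only a limit is reported.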

Compound 3, half-maximal inhibitory concentration: 49800 nM
Compound 3: the middle estimate sits 1.6-fold (0.21 log units) above what was measured; low and high end bracket the measured number.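

Among the compounds shown here, compound 1 has no number in this assay to set against compound 3, and no step between the two can be read. No measured evidence bears on this result. Going by these compounds, what the methyl changes in this pair stays open.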